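Chloro added to the sulfonamide-bearing pyrazole of compound 2

The source may hold more compounds than are shown below. What is called first, only, known or untested is meant among the compounds shown, and "the series" means these compounds.

Within the data shown here, compound 2 `NS(=O)(=O)c1ccc(-n2nc(-c3ccccc3)cc2-c2cc(O)ccc2O)cc1` is one of two compounds measured in a functional assay on cells (Cancer cell lines, Homo sapiens) for cytotoxicity, read by sulforhodamine B assay, with a stated time of 48 h (a lower number here means a stronger inhibitor of growth, a higher number a weaker inhibitor of growth), and in that assay compound 2 gives 77600 nM, the higher of the two numbers. Its nearest neighbour, compound 1 `Oc1ccc(O)c(-c2cc(-c3ccc(Cl)cc3)nn2-c2ccccc2)c1`, differs from it in more than one place, and in this assay compound 1 gives 14600 nM, a gap described as beyond the scatter. Compound 3 `NS(=O)(=O)c1ccc(-n2nc(-c3ccc(Cl)cc3)cc2-c2cc(O)ccc2O)cc1` has not been measured. It differs from compound 2 in a single respect: chloro in place of hydrogen on an aromatic carbon. Among the measured compounds shown here, no measured pair shows this change on its own, so its effect is not known from a direct comparison. Since compound 1, which carries the same chloro group, gives 14600 nM, a modest move toward lower numbers is expected, though with wide uncertainty. The estimated step from compound 2 to compound 3 is a 1.7-fold lower number from compound 2 to compound 3 (0.24 log units; within the scatter). Compound 3 is estimated to give 45000 nM in this assay, within a range from 15000 nM to 130000 nM.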

Compound 3, concentration for 50% growth inhibition: 13400 nM
Estimate against measurement, compound 3: 3.4-fold (0.53 log units) above; the whole stated range lies above it.
By their numbers in this assay, from the lowest: compounds 3 and 1 (each within the scatter of the next); then compound 2.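

In this assay, among these compounds, the change from phenyl to 4-chlorophenyl, read here on its own for the first time, gives a 5.8-fold lower number from compound 2 to compound 3 (0.76 log units; beyond the scatter) and so shows that this position on the ring matters in a compound carrying the sulfamoyl group. Where the 4-chlorophenyl is already present, sulfamoyl in place of hydrogen gives a 1.1-fold lower number from compound 1 to compound 3 (0.04 log units; within the scatter) and cannot be told from the scatter, so compound 1 and compound 3 stand level. No measurement shown here offers a reason for either result. 

The compounds shown leave open whether the sulfamoyl group would be equally without effect on a compound lacking the chloro group. They also leave open whether a bromo group, a methoxy group or an amine at this position would give a number like that of the chloro group.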